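Chloro-to-methyl swap on the anilide ring across two cores

This account rests on a few compounds, and the source may have more. Where it says the series, first, only, none or still open, it means among the compounds named here.

Compound 1 `O=C1Nc2ccc(Br)cc2/C1=N/NC(=S)Nc1ccc(Cl)cc1` and compound 2 `Cc1ccc(NC(=S)N/N=C2\C(=O)Nc3ccc(Br)cc32)cc1` share one core; in a functional assay on CCRF-CEM cells (Homo sapiens), with a stated time of 72 h (a lower number here means a stronger inhibitor, a higher number a weaker inhibitor), compound 1 gives 61000 nM and compound 2 gives 6800 nM. The change between them is methyl in place of chloro on an aromatic carbon, and it made the step of a 9.0-fold lower number from compound 1 to compound 2 (0.95 log units; beyond the scatter). Compound 3 `O=C1Nc2cc(Cl)c(F)cc2/C1=N/NC(=S)Nc1ccc(Cl)cc1` carries a second core; the difference between the two cores is not broken down here. In this assay compound 3 gives 48000 nM, which sits near compound 1. Compound 4 `Cc1ccc(NC(=S)N/N=C2\C(=O)Nc3cc(Cl)c(F)cc32)cc1` applies the same change to compound 3: methyl in place of chloro on an aromatic carbon. For the measured compounds named here, with only one earlier instance, the expectation for compound 4 rests on that single step and on compound 3 as the starting point. The step from compound 3 to compound 4 in this assay is expected to be about an 8.7-fold lower number from compound 3 to compound 4 (0.94 log units; beyond the scatter). Compound 4 is therefore estimated at 5500 nM, with a likely range from 2500 nM to 13000 nM.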

Compound 4, half-maximal inhibitory concentration: 132000 nM
Compound 4: middle estimate off by 24-fold (1.38 log units), on the low side; measured number outside the range, above it.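

In this assay, methyl in place of chloro gives a 2.8-fold higher number from compound 3 to compound 4 (0.44 log units; beyond the scatter), so the gain seen on the core of compound 1 does not carry over to the core of compound 3. The two steps run in opposite directions and differ clearly: the same change on two cores in this assay, a 9.0-fold lower number (0.95 log units; beyond the scatter) from compound 1 to compound 2 and a 2.8-fold higher number (0.44 log units; beyond the scatter) from compound 3 to compound 4, 25-fold (1.39 log units) apart, beyond the scatter of two such steps. This shows that, for these two pairs, the outcome of the change depends on the core; it does not show which feature of the core decides the direction, and two pairs give no rule for a further core.

Open, going by these compounds, is how other groups in place of the chloro, such as an amine or a carboxylic acid, behave on each core. Also open, on these data alone, is whether the bromo of compound 1's core or the chloro and fluoro of compound 3's core govern the reversal.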